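Chloro for methoxy across two related cores

The compounds below may be only part of what the source reports. "The series", "measured", "known", "first", "only" and "open" are said of these compounds alone.

Compound 2 `COc1ccccc1C1CCc2nc[nH]c2C1` and compound 1 `Clc1ccccc1C1CCc2nc[nH]c2C1` share one core; compound 3 `COc1ccccc1C1Cc2nccn2C1` and compound 4 `Clc1ccccc1C1Cc2nccn2C1` share another. The difference between the two cores is not broken down here. In a functional assay on CHO cells for agonist activity at Alpha-1A adrenergic receptor (Homo sapiens), read by FLIPR and calcium flux (on this read-out lower numbers stand for smaller maximal responses and higher numbers for larger maximal responses), compound 2 gives 95% and compound 1 gives 60%, a step of a number 35 percentage points lower from compound 2 to compound 1 (beyond the scatter) made by chloro in place of methoxy on an aromatic carbon. In this assay compound 3 gives 82%. Compound 4 carries chloro in place of methoxy on an aromatic carbon, the same kind of change, though the place is not identical: in the first pair it sits ortho to a group of 9 heavy atoms, in the second ortho to a group of 8 heavy atoms. This change occurs twice among the compounds shown. In this assay a step of a number 32 percentage points lower from compound 3 to compound 4 (beyond the scatter) is expected, because the same change made a number 35 percentage points lower from compound 2 to compound 1 (beyond the scatter). Compound 4 is therefore estimated at 50%, with a likely range from 30% to 70%.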

Compound 4, largest response reached (Emax), in percent of the reference or control that the assay uses: 56%
Compound 4: middle estimate off by 6 percentage points, on the low side; the measured number falls inside the stated range.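

In this assay chloro in place of methoxy on an aromatic carbon gives a number 26 percentage points lower from compound 3 to compound 4 (beyond the scatter) on the second core, and the step agrees with the one on the first core: the same change on two cores in this assay, a number 35 percentage points lower (beyond the scatter) from compound 2 to compound 1 and a number 26 percentage points lower (beyond the scatter) from compound 3 to compound 4, 9 percentage points apart, within the scatter of two such steps

On this read-out, the change therefore carried over between these two cores in direction and in approximate size. For the compounds shown here, with only two pairs and a single read-out, this does not show that the step would hold on a further core, nor does it explain why the maximal response falls.

The compounds shown carry only methoxy or chloro at this place, so the effect of an amine, a carboxylic acid or a longer chain there remains open. Also open, going by these compounds, is how either group would behave on another carbon of the six-membered aromatic ring.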